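This account rests on a few compounds, and the source may have more. Where it says the series, first, only, none or still open, it means among the compounds named here.

Compound 2 `Cc1c(C)c2c(c(C)c1O)CCC(C)(CN1CCN(c3ncccn3)CC1)O2` in a functional assay (brain) for inhibition, with Rattus norvegicus as the target (on this read-out lower numbers stand for stronger inhibition and higher numbers for weaker inhibition), gives 1000 nM, level with compound 1 `Cc1c(C)c2c(c(C)c1O)CCC(C)(CN1CCN(c3ccccn3)CC1)O2`, which in this assay gives 1000 nM. Going by the values given here, the one step measured so far, no change at the digits printed from compound 1 to compound 2 (within the scatter), put pyrimidin-2-yl in place of pyridin-2-yl on an amine nitrogen in a ring and left the read-out unchanged. Compound 3 `COc1ccc(N2CCN(CC3(C)CCc4c(C)c(O)c(C)c(C)c4O3)CC2)cc1` differs from compound 2 by 4-methoxyphenyl in place of pyrimidin-2-yl on an amine nitrogen in a ring. Among the compounds with values here, only that flat step bears on this change, so no movement beyond the scatter is expected. Compound 3 is estimated at 1000 nM, with a range of 350 nM to 3000 nM. The expected step is no change at the digits printed from compound 2 to compound 3 (within the scatter).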

Compound 3, half-maximal inhibitory concentration: 200 nM
Compound 3: the middle estimate sits 5.0-fold (0.70 log units) above what was measured; measured number outside the range, below it.
By their numbers in this assay, from the lowest: compound 3; then compounds 1 and 2 (each within the scatter of the next).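

In this assay, the group on this amine nitrogen is not indifferent after all: 4-methoxyphenyl gives a 5.0-fold lower number from compound 2 to compound 3 (0.70 log units; beyond the scatter) and also a 5.0-fold lower number from compound 1 to compound 3 (0.70 log units; beyond the scatter) on the same core, whereas swapping one nitrogen-bearing ring for the other changed nothing. The position therefore responds to at least this aromatic ring of carbon only with its methoxy group. Nothing available explains the step.

Whether the methoxy group or the carbon-only ring accounts for it stays open. A plain phenyl on this nitrogen would separate the two.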